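The source may hold more compounds than are shown below. What is called first, only, known or untested is meant among the compounds shown, and "the series" means these compounds.

Measured so far:
Compound 1 `COC(=O)[C@H](COC(C)(C)C)NC(=O)N1CCC2(CC1)C(=O)N(c1cccc(F)c1)C2c1ccc(Cl)cc1`; in an assay on HEK293 cells for inhibition of Voltage-dependent T-type calcium channel subunit alpha-1H (Homo sapiens), read by patch clamp, using a membrane potential dye (a higher number here means a weaker inhibitor, a lower number a stronger inhibitor), compound 1 gives 251 nM.
Compound 2 `C[C@H](NC(=O)N1CCC2(CC1)C(=O)N(c1cccc(F)c1)C2c1ccc(Cl)cc1)c1ccccc1`; in this assay compound 2 gives 139 nM.

Compound 2 holds the lower of the two numbers, but the step of a 1.8-fold lower number from compound 1 to compound 2 (0.26 log units; within the scatter) is within the scatter, so compound 2 and compound 1 are not separated on this evidence.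

Compound 3 `C[C@@H](NC(=O)N1CCC2(CC1)C(=O)N(c1cccc(F)c1)C2c1ccc(Cl)cc1)c1ccccc1` differs from compound 2 as follows: the two compounds have the same atoms and bonds; at least one stereo element is drawn with a configuration in one of them and without one in the other: 1 of 2 stereo elements differ; a stereocentre at a saturated chain carbon is drawn S in compound 2 and R in compound 3. For the measured compounds named here, the only measured step, a 1.8-fold lower number from compound 1 to compound 2 (0.26 log units; within the scatter), exchanges the group on the urea nitrogen and leaves configuration untouched; it says nothing about inverting the stereocentre. Going by the values given here, no measured step bears on this change, so the expected step of a 1.8-fold higher number from compound 2 to compound 3 (0.25 log units; within the scatter) is set close to no change, with a wide range to allow for a real configuration effect in either direction. For compound 3 in this assay the estimate is 250 nM, within 70 nM to 1500 nM.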

Compound 3, half-maximal inhibitory concentration: 351 nM
Compound 3: middle estimate off by 1.4-fold (0.15 log units), on the low side; the measured number falls inside the stated range.
By their numbers in this assay, from the lowest: compounds 2, 1 and 3 (each within the scatter of the next, the first and the last beyond it).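

Configuration at the saturated chain carbon of the 1-phenylethyl group registers in this assay: a 2.5-fold higher number from compound 2 to compound 3 (0.40 log units; beyond the scatter), the first step in the series beyond the scatter, though a modest one. The S form in compound 2 gives the lower number, and the only structural difference within the pair is this: the fact that one of compounds 2 and 3 is drawn with a defined configuration and the other without, at the place where they differ. The group exchange reads differently in the R form: with a 1.4-fold higher number from compound 1 to compound 3 (0.15 log units; within the scatter), 1-phenylethyl and 1-(methoxycarbonyl)-2-(tert-butoxy)ethyl remain unseparated, as they do in the step of a 1.8-fold lower number from compound 1 to compound 2 (0.26 log units; within the scatter).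

On these data alone, whether inverting the stereocentre in the 1-(methoxycarbonyl)-2-(tert-butoxy)ethyl group has a comparable effect remains open. Also open, as far as these compounds go, is how a benzyl group or a carboxylic acid in place of the methyl ester would read in this assay.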